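The source may report more compounds than this note shows. Statements on the series, on what has been measured and on what is new or still open speak of the compounds shown alone.

Compound 3 `FC(F)(F)c1ccc(Nc2nc(N3CCNCC3)nc3sc(Nc4c(Cl)cccc4Cl)nc23)cc1` carries a piperazin-1-yl group on the shared core. In a functional assay on HEK293 cells for antagonist activity at transient receptor potential cation channel subfamily V member 1 (Rattus norvegicus), read by calcium flux (on this read-out higher numbers stand for weaker inhibition and lower numbers for stronger inhibition), compound 3 reaches only a limit, > 5000 nM. Compound 1 `FC(F)(F)c1ccc(Nc2ncnc3sc(Nc4c(Cl)cccc4Cl)nc23)cc1`, with hydrogen at that carbon, gives 3 nM in this assay, and compound 2 `FC(F)(F)c1ccc(Nc2nc(N3CCCC3)nc3sc(Nc4c(Cl)cccc4Cl)nc23)cc1`, with pyrrolidin-1-yl, gives 36 nM. The measured steps were a 12-fold higher number from compound 1 to compound 2 (1.08 log units; beyond the scatter), an at least 1600-fold higher number from compound 1 to compound 3 (3.22 log units; beyond the scatter) and an at least 130-fold higher number from compound 2 to compound 3 (2.14 log units; beyond the scatter), the last two ending at the limit of > 5000 nM in this assay, at which 1 of the 3 values shown sits. Compound 4 `CCN(CC)c1nc(Nc2ccc(C(F)(F)F)cc2)c2nc(Nc3c(Cl)cccc3Cl)sc2n1` differs from compound 3 by diethylamino in place of piperazin-1-yl on an aromatic carbon. The diethylamino group, like pyrrolidin-1-yl, brings no hydrogen-bond donor, so a return toward the level of compound 2 is expected, a large fall an at least 83-fold lower number from compound 3 to compound 4 (1.92 log units; beyond the scatter). Compound 4 is therefore estimated at 60 nM, with a range from 15 nM to 300 nM.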

Compound 4, half-maximal inhibitory concentration: 34 nM
Compound 4: middle estimate off by 1.8-fold (0.25 log units), on the high side; low and high end bracket the measured number.
By their numbers in this assay, from the lowest: compound 1; then compounds 4 and 2 (each within the scatter of the next). At a limit, above all of these: compound 3.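

With a 1.1-fold lower number from compound 2 to compound 4 (0.02 log units; within the scatter), diethylamino, which has no ring, and the ring of pyrrolidin-1-yl cannot be told apart at this position, so a ring is not required here. Hydrogen on this carbon still gives the lower number, with an 11-fold higher number from compound 1 to compound 4 (1.05 log units; beyond the scatter). The return from piperazin-1-yl, an at least 140-fold lower number from compound 3 to compound 4 (2.16 log units; beyond the scatter), sets only a minimum size for the change, as compound 3 stands at a limit: the limit of > 5000 nM in this assay, at which 1 of the 4 values shown sits.

From the compounds shown here alone, whether the nitrogen-hydrogen of piperazin-1-yl is what matters stays open. 4-Methylpiperazin-1-yl or morpholin-4-yl would keep a six-membered ring without that hydrogen and could separate the two.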